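Hydroxyalkyl amide series at TRPM8: loss of the hydroxyl

The source may report more compounds than this note shows. Statements on the series, on what has been measured and on what is new or still open speak of the compounds shown alone.

Measured compounds:
compound 1, `Cc1ccc(OCC(=O)N(Cc2cccs2)C2COC2)cc1`, 23000 nM
compound 2, `Cc1ccc(OCC(=O)N(CCCO)Cc2cccs2)cc1`, 3000 nM
compound 3, `Cc1ccc(OCC(=O)N(CCO)Cc2cccs2)cc1`, 900 nM

All three share one core and differ only in the group on the amide-type nitrogen. In an assay on HEK293 cells for agonist activity at transient receptor potential cation channel subfamily M member 8 (Homo sapiens), read by fluorescence and calcium flux, with a stated time of 15 min (on this read-out higher numbers stand for an effect only at larger amounts of compound and lower numbers for an effect already at smaller amounts), compound 3 gives the lowest number of the set: a 26-fold lower number from compound 1 to compound 3 (1.41 log units; beyond the scatter) and a 3.3-fold lower number from compound 2 to compound 3 (0.52 log units; beyond the scatter), both beyond the scatter, so compound 3 is the most active of the three by a clear margin.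

Compound 4, `Cc1ccc(OCC(=O)N(C)Cc2cccs2)cc1`, has not been measured. It differs from compound 3 in one place: hydrogen in place of hydroxymethyl on a saturated chain carbon bound to an amide-type nitrogen. Among the compounds with values here, the steps that bear on this change are the shortening of the hydroxyalkyl chain, a 3.3-fold lower number from compound 2 to compound 3 (0.52 log units; beyond the scatter), and the exchange of the oxetanyl ring for the hydroxyethyl chain, a 26-fold lower number from compound 1 to compound 3 (1.41 log units; beyond the scatter). Both point to the hydroxyl-bearing short chain as the best group seen so far, and compound 4 keeps no oxygen on the nitrogen substituent at all. The step from compound 3 to compound 4 is therefore expected to be a rise, a 5.6-fold higher number from compound 3 to compound 4 (0.74 log units; beyond the scatter), with wide uncertainty. Compound 4 is estimated at 5000 nM, within 1500 nM to 20000 nM.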

Compound 4, half-maximal effective concentration: 400 nM
Compound 4: middle estimate off by 13-fold (1.10 log units), on the high side; measured number below the stated range.
By their numbers in this assay, from the lowest: compound 4; then compound 3; then compound 2; then compound 1.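

In this assay, the hydroxyl is not needed on this nitrogen substituent: with hydrogen in place of hydroxymethyl there is a 2.3-fold lower number from compound 3 to compound 4 (0.35 log units; beyond the scatter), the opposite of a loss. Along the open chains, from 3-hydroxypropyl through 2-hydroxyethyl to methyl, the number falls at each step, with a 7.5-fold lower number from compound 2 to compound 4 (0.88 log units; beyond the scatter) overall, and the ring-bearing compound 1 stands furthest off, with a 58-fold lower number from compound 1 to compound 4 (1.76 log units; beyond the scatter). No supporting data bear on why the smallest group of the set gives the lowest number.

As far as these compounds go, whether the trend depends on chain length or on the hydroxyl itself stays open, since an unsubstituted ethyl or propyl group on the nitrogen would separate the two. Also open, from the compounds shown here alone, is how an amine or a carboxylic acid at the end of the chain would read here.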